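A few compounds are considered here, and "the series" means these few. Any claim that something is new, unique, unknown or untested is made for them only; others in the source may bear on it.

Working notes on a small pyrazole-amine series.

Compound 1 `Nc1cc(-c2ccc(Cl)cc2)nn1-c1cccc(Cl)c1` and compound 3 `CN(C)/C=N/c1cc(-c2ccc(Cl)cc2)nn1-c1cccc(Cl)c1` share one core and differ only at one aromatic carbon. In a functional assay on NCI-H226 cells (Homo sapiens) for inhibition, read by MTT assay, with a stated time of 72 h (on this read-out lower numbers stand for stronger inhibition of growth and higher numbers for weaker inhibition of growth), compound 1 gives 75100 nM, and in this assay compound 3 gives 75600 nM. The change one nitrogen atom in place of a group of 5 heavy atoms (3 carbon, 2 nitrogen; no ring), on an aromatic carbon gave a 1.0-fold lower number from compound 3 to compound 1 (0.00 log units; within the scatter), so the two numbers are read as equivalent.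

Compound 2 `Cc1ccc(-c2nn(-c3cccc(Cl)c3)c(/N=C/N(C)C)c2C=O)cc1` carries a different core; the difference between the two cores is not broken down here. In this assay compound 2 gives 8900 nM, the lowest number of the three, with compound 1 and compound 3 both beyond the scatter above it.

Compound 4 `Cc1ccc(-c2nn(-c3cccc(Cl)c3)c(N)c2C=O)cc1` is not yet measured. Among the measured compounds shown here, it arises from compound 2 by one nitrogen atom in place of a group of 5 heavy atoms (3 carbon, 2 nitrogen; no ring), on an aromatic carbon, the same kind of change as the one that turns compound 3 into compound 1, not the same one: the place in compound 2 is additionally next to the ring atom that bears a formyl group, and it lies two ring bonds from the ring atom that bears a 4-methylphenyl group rather than a 4-chlorophenyl group.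

For compound 4 in this assay the expected step is a 1.0-fold higher number from compound 2 to compound 4 (0.00 log units; within the scatter), resting on the flat outcome of a 1.0-fold lower number from compound 3 to compound 1 (0.00 log units; within the scatter) seen for the same kind of change on compound 3. Compound 4 is therefore estimated at 9000 nM, with the expected range running from 4000 nM to 22000 nM.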

Compound 4, concentration for 50% growth inhibition: 71800 nM
Estimate against measurement, compound 4: 8.0-fold (0.90 log units) below, and the stated range ends below it.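

Replacing the group of 5 heavy atoms with amino on the core of compound 2 gives in this assay an 8.1-fold higher number from compound 2 to compound 4 (0.91 log units; beyond the scatter), so on this core the group of 5 heavy atoms goes with stronger inhibition of growth than amino does. The same change therefore does not carry over as a flat step from one core to the other in this series: the same change on two cores in this assay, a 1.0-fold lower number (0.00 log units; within the scatter) from compound 3 to compound 1 and an 8.1-fold higher number (0.91 log units; beyond the scatter) from compound 2 to compound 4, 8.1-fold (0.91 log units) apart, beyond the scatter of two such steps. This rests on a single pair per core and does not show which difference between the cores goes with the gap, as the formyl group and the 4-methylphenyl group in place of 4-chlorophenyl occur together, nor does it give any reason for the gap or a rule for other cores.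

Still open, as far as these compounds go, is whether the gap follows the formyl group or the 4-methylphenyl group, which a matched pair carrying only one of the two would separate. Also open, from the compounds shown here alone, is how the same change behaves when a nitrile, a carboxylic acid or a hydroxymethyl group stands in the place of the formyl group, or when a dimethylamino group replaces amino.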